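The source may report more compounds than this note shows. Statements on the series, on what has been measured and on what is new or still open speak of the compounds shown alone.

Working notes on the shared core. Compound 1 `Nc1nc(N)c2cc(CSC(=S)N3CCN(c4ccc(O)cc4)CC3)ccc2n1` and compound 2 `Cc1ccc(N2CCN(C(=S)SCc3ccc4nc(N)nc(N)c4c3)CC2)c(C)c1` differ only at the amine nitrogen in the ring. In a functional assay on HeLa cells (Homo sapiens) for antiproliferative activity, read by MTT assay, with a stated time of 72 h (a higher number here means a weaker inhibitor, a lower number a stronger inhibitor), compound 1 gives 5180 nM, and compound 2 gives 3190 nM; the step of a 1.6-fold lower number from compound 1 to compound 2 (0.21 log units; within the scatter) is within the scatter, so the two numbers are not separated. Compound 2 stands lowest of the two numbers, with compound 1 nearest and not distinguishable from it.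

Compound 3 `Nc1nc(N)c2cc(CSC(=S)N3CCN(c4ccc(F)cc4)CC3)ccc2n1` is not yet measured. The change from compound 2 is 4-fluorophenyl in place of 2,4-dimethylphenyl on an amine nitrogen in a ring. Among the measured compounds shown here, the only step that bears on this position is the one from compound 1 to compound 2, and it was within the scatter; no step involving 4-fluorophenyl exists in the set. The expectation for compound 3 in this assay is therefore no step beyond the scatter, a 1.3-fold higher number from compound 2 to compound 3 (0.10 log units; within the scatter). Compound 3 is estimated at 4000 nM, with a range from 1800 nM to 9000 nM.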

Compound 3, half-maximal inhibitory concentration: 1840 nM
Beside the measured number, compound 3's estimate is 2.2-fold (0.34 log units) above it; measured number inside the range.
By their numbers in this assay, from the lowest: compounds 3, 2 and 1 (each within the scatter of the next, the first and the last beyond it).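

In this assay this position now gives a step that clears the scatter: fluoro in place of hydroxy on an aromatic carbon gives a 2.8-fold lower number from compound 1 to compound 3 (0.45 log units; beyond the scatter), a modest change and the first separation in the series. The other new step, a 1.7-fold lower number from compound 2 to compound 3 (0.24 log units; within the scatter), does not separate 4-fluorophenyl from 2,4-dimethylphenyl, so compound 2 remains unresolved from both compound 1 and compound 3, and only the two compounds at the ends of the set are distinguished. No measurement in hand accounts for the separation.

On these data alone, it remains open whether the step reflects the arrival of fluoro or the departure of hydroxy, which an unsubstituted phenyl or a chloro or methoxy group on the same carbon could help settle. As far as these compounds go, how a benzyl group on that amine nitrogen would read is also open.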